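A few compounds are considered here, and "the series" means these few. Any claim that something is new, unique, unknown or untested is made for them only; others in the source may bear on it.

In a functional assay on SK-OV-3 cells (Homo sapiens) for antiproliferative activity, read by MTT assay (on this read-out higher numbers stand for weaker inhibition and lower numbers for stronger inhibition), compound 1, `CC1(c2ccccc2)CN(S(=O)(=O)c2ccc3c(c2)CCCN3C(=O)C(F)(F)F)C(=O)N1`, gives > 20000 nM, which is a limit of the assay and not a number. Compound 2, `CSc1ccc(NC(=O)N2CCCc3cc(S(=O)(=O)N4CC(C)(c5ccccc5)NC4=O)ccc32)cc1`, gives > 20000 nM, and this too is only a limit. For the measured compounds named here, compound 2 thus has no exact position on the scale, and the one other value beside it is also a limit. Going by the values given here, the only measured step is a step that the two limits leave unreadable from compound 1 to compound 2, so it offers no size to carry forward. The remaining guide is the limit of > 20000 nM in this assay, at which 2 of the 2 values shown sit.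

Compound 3, `COc1ccc(NC(=O)N2CCCc3cc(S(=O)(=O)N4CC(C)(c5ccccc5)NC4=O)ccc32)cc1`, has methoxy in place of methylsulfanyl on an aromatic carbon, para to a large group: methoxy in place of methylsulfanyl on an aromatic carbon. Among the compounds with values here, no measured step covers this exchange, so no change beyond the scatter is expected in this assay, and no direction can be assigned. The expectation rests on compound 2, whose limit of > 20000 nM is the nearest reference. The expected step is a number no higher from compound 2 to compound 3 (the limit leaves the size open). Compound 3 is estimated at 20000 nM, with an expected range from 9000 nM to 45000 nM, and it may well be reported only as a limit.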

Compound 3, half-maximal inhibitory concentration: 9470 nM
Compound 3: the middle estimate sits 2.1-fold (0.32 log units) above what was measured, within the range that was stated.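

In this assay, for the compounds shown here, compound 3 is the only one of the three compounds to give a number, while the other two stand at a limit of the assay: the limit of > 20000 nM in this assay, at which 2 of the 3 values shown sit. Going by these compounds alone, the exchange of methylsulfanyl for methoxy on an aromatic carbon, para to a large group, is thus the first change at this position whose direction can be read, as an at least 2.1-fold lower number from compound 2 to compound 3 (0.32 log units; beyond the scatter) and its full size stays open since compound 2 gives only a limit. The exchange of trifluoromethyl for (4-methoxyphenyl)amino on a carbonyl carbon reads as an at least 2.1-fold lower number from compound 1 to compound 3 (0.32 log units; beyond the scatter) and differs from the step to (4-(methylsulfanyl)phenyl)amino, which the two limits leave unreadable, so a readable value among these compounds depends on the group at the aromatic carbon as well as on the group on the carbonyl carbon.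

The compounds shown leave open whether a hydroxyl, a chlorine atom, an amine or a longer alkoxy chain at this aromatic carbon would give a lower number than methoxy. Within the data shown here, they also leave open how far the number could fall, since only one compound here gives a value that is not a limit.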